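Moving the chlorine on the pendant phenyl ring

The source may hold more compounds than are shown below. What is called first, only, known or untested is meant among the compounds shown, and "the series" means these compounds.

Compound 1, `Cc1ccccc1C(c1c(-c2ccccc2)c[n+]([O-])c2c(C)noc12)c1c(-c2ccccc2)c[n+]([O-])c2c(C)noc12`: in a functional assay on Ehrlich cells (Homo sapiens) for cytotoxicity, read by MTT assay, with a stated time of 48 h (a higher number here means a weaker inhibitor, a lower number a stronger inhibitor), compound 1 gives 65.1 ug/mL.
Compound 2, `Cc1noc2c(C(c3ccccc3Cl)c3c(-c4ccccc4)c[n+]([O-])c4c(C)noc34)c(-c3ccccc3)c[n+]([O-])c12`: in this assay compound 2 gives 70.4 ug/mL.

Compound 1 has the lowest of the two numbers shown, but its nearest neighbour is compound 2, and the change a 1.1-fold higher number from compound 1 to compound 2 (0.03 log units; within the scatter) is within the scatter, so the two cannot be told apart. Compound 3, `Cc1noc2c(C(c3ccc(Cl)cc3)c3c(-c4ccccc4)c[n+]([O-])c4c(C)noc34)c(-c3ccccc3)c[n+]([O-])c12`, is not yet measured. It differs from compound 1 by 4-chlorophenyl in place of 2-methylphenyl on a saturated chain carbon bound to two aromatic carbons. Going by the values given here, the only measured step that bears on this change is the one from compound 1 to compound 2, in which a chloro replaced a methyl on the same pendant ring and the number hardly moved. On that basis no step beyond the scatter is expected in this assay for compound 3, in either direction, so the estimated step is a 1.0-fold higher number from compound 1 to compound 3 (0.02 log units; within the scatter). The estimate for compound 3 is therefore 68 ug/mL, with a range from 38 ug/mL to 120 ug/mL.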

Compound 3, half-maximal inhibitory concentration: 60.6 ug/mL
For compound 3 the middle estimate is 1.1-fold (0.05 log units) above the measured one, within the range that was stated.
By their numbers in this assay, from the lowest: compounds 3, 1 and 2 (each within the scatter of the next).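

In this assay the change to 4-chlorophenyl from 2-methylphenyl gives a 1.1-fold lower number from compound 1 to compound 3 (0.03 log units; within the scatter) and the change to 4-chlorophenyl from 2-chlorophenyl gives a 1.2-fold lower number from compound 2 to compound 3 (0.07 log units; within the scatter) on the saturated chain carbon bound to two aromatic carbons. The earlier pair showed only that chloro in place of methyl on the pendant ring left the number within the scatter; the new steps show the same for moving the chlorine on that ring, so compounds 1, 2 and 3 cannot be told apart. No measurement shown gives a reason for this result. The compounds shown leave open whether an amine, a carboxylic acid or a longer chain on the pendant ring would move the number beyond the scatter. They also leave open whether any change to the shared core would do so.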